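The compounds below may be only part of what the source reports. "The series", "measured", "known", "first", "only" and "open" are said of these compounds alone.

Measured in a functional assay on SGC-7901 cells (Homo sapiens) for antiproliferative activity, read by MTT assay, with a stated time of 48 h; on this read-out lower numbers stand for an effect already at smaller amounts and higher numbers for an effect only at larger amounts of compound:

Compound 1 `CC1=NN(C(=O)C(F)(F)F)C(c2ccccc2O)C1`: 2060 nM
Compound 2 `CC1=NN(C(=O)CCl)C(c2cc(F)ccc2O)C1`: 7000 nM
Compound 3 `CC1=NN(S(=O)(=O)c2ccc([N+](=O)[O-])cc2)C(c2cc(Br)ccc2O)C1`: 27300 nM

Compound 3 has the highest number of the three, so it needs the largest amount of compound to show an effect. Its value lies beyond the usual scatter from both of the others, with compound 2 the nearer and compound 1 the further away.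

Compound 4 `COc1ccc(S(=O)(=O)N2N=C(C)CC2c2cc(Br)ccc2O)cc1` has methoxy in place of nitro on an aromatic carbon, para to a large group: methoxy in place of nitro on an aromatic carbon. Within the data shown here, no measured pair in this assay isolates a change at this place, so any expectation here is loose. With compound 3 at 27300 nM, the top of the measured numbers, a small move toward a lower number seems more likely than a rise, and it may not clearly exceed the scatter. The expected change is a 1.8-fold lower number from compound 3 to compound 4 (0.26 log units; within the scatter). For compound 4 the estimated value is 15000 nM, with an expected range from 6000 nM to 40000 nM.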

Compound 4, half-maximal effective concentration: 21100 nM
Estimate against measurement, compound 4: 1.4-fold (0.15 log units) below, and the stated range covers the measured number.
By their numbers in this assay, from the lowest: compound 1; then compound 2; then compounds 4 and 3 (each within the scatter of the next).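

Among these compounds, this is the first pair in this assay that differs in one place only, and it gives a 1.3-fold lower number from compound 3 to compound 4 (0.11 log units; within the scatter). At this place, on a six-membered aromatic ring of carbon only and para to a large group, methoxy in place of nitro therefore gives two numbers that cannot be told apart, so this exchange of groups leaves no visible mark on the read-out. Nothing measured here explains why the two compounds fall so close together.

From the compounds shown here alone, whether an amine, a carboxylic acid or a longer chain at this place would move the number beyond the scatter remains open. A single pair also leaves open whether nitro and methoxy would stay this close if the rest of the molecule carried other groups.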